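The source may hold more compounds than are shown below. What is called first, only, known or untested is meant among the compounds shown, and "the series" means these compounds.

Measured compounds:
Compound 1, `O=C(Nc1cc(C(F)(F)F)cc(C(F)(F)F)c1)c1n[nH]nc1O`, gives > 100000 nM in an assay on isolated protein for inhibition of mitogen-activated protein kinase kinase kinase 14 (Homo sapiens), read by ADP-Glo, with a stated time of 60 min, in the presence of a further agent that is not named here (on this read-out lower numbers stand for stronger inhibition and higher numbers for weaker inhibition), which is a limit of the assay.
Compound 2, `O=C(Nc1cc(C(F)(F)F)cc(C(F)(F)F)c1)c1nsnc1O`, gives > 100000 nM in this assay, also a limit.
Compound 3, `Cc1c(C(=O)Nc2cc(C(F)(F)F)cc(C(F)(F)F)c2)c(O)nn1C`, gives > 100000 nM in this assay, again a limit.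

Compound 2 thus stands at the limit of the assay rather than at a number. The same holds throughout the set: the limit of > 100000 nM in this assay, at which 3 of the 3 values shown sit. The steps among the measured compounds, a step that the two limits leave unreadable from compound 1 to compound 2, a step that the two limits leave unreadable from compound 1 to compound 3 and a step that the two limits leave unreadable from compound 2 to compound 3, all exchange the ring on the carbonyl carbon and none of them has a readable size.

Compound 4, `O=C(Nc1cccc(C(F)(F)F)c1)c1nsnc1O`, is not yet measured. It differs from compound 2 in hydrogen in place of trifluoromethyl on an aromatic carbon. Going by the values given here, none of the measured steps touches this position; each alters the ring on the carbonyl carbon while the aryl group carrying two trifluoromethyl groups is kept. Among the compounds with values here, no measured step therefore bears directly on this change, and the only guidance is that compound 2 shows no inhibition within the range of the assay. Compound 4 is expected to remain at that limit, with the step that the limit leaves unreadable from compound 2 to compound 4 expected to be nothing beyond the scatter. The estimate for compound 4 in this assay is 150000 nM, between 50000 nM and 500000 nM.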

Compound 4, half-maximal inhibitory concentration: > 100000 nM
Compound 4 gave a limit, no number; the forecaster's own chance of this, stated with the estimate: 85%; the middle value does not contradict the limit.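

The step from compound 2 to compound 4, hydrogen in place of trifluoromethyl, cannot be read, as both compounds give only a limit and no number. The whole set stands at one value: the limit of > 100000 nM in this assay, at which 4 of the 4 values shown sit.

The compounds shown leave open how large any of these changes is and what structure would give a measurable inhibition.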